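From 2-methoxyphenyl to 3-methylphenyl at the assay limit

The compounds below may be only part of what the source reports. "The series", "measured", "known", "first", "only" and "open" are said of these compounds alone.

Measured so far in a functional assay on DU-145 cells (Homo sapiens) for antiproliferative activity, read by MTT assay, with a stated time of 48 h (a higher number here means a weaker inhibitor, a lower number a stronger inhibitor), with each value a limit of the assay:
- Compound 1 `COc1ccccc1-n1cc(COC(=O)/C(C)=C/CC/C(C)=C/CC/C(C)=C/CC[C@@H]2[C@@]3(C)CCC(=O)C(C)(C)[C@H]3CC[C@@]2(C)O)nn1` gives > 150000 nM as a limit
- Compound 2 `C/C(=C\CC/C(C)=C/CC[C@@H]1[C@@]2(C)CCC(=O)C(C)(C)[C@H]2CC[C@@]1(C)O)CC/C=C(\C)C(=O)OCc1cn(-c2ccccc2C(F)(F)F)nn1` gives > 150000 nM as a limit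
- Compound 3 `C/C(=C\CC/C(C)=C/CC[C@@H]1[C@@]2(C)CCC(=O)C(C)(C)[C@H]2CC[C@@]1(C)O)CC/C=C(\C)C(=O)OCc1cn(-c2ccccc2[N+](=O)[O-])nn1` gives > 150000 nM as a limit

In this assay compound 1 has no number, only > 150000 nM as a limit of the assay. The whole measured set shares one position, with the limit of > 150000 nM in this assay, at which 3 of the 3 values shown sit, as the common mark.

Compound 4 `C/C(=C\CC/C(C)=C/CC[C@@H]1[C@@]2(C)CCC(=O)C(C)(C)[C@H]2CC[C@@]1(C)O)CC/C=C(\C)C(=O)OCc1cn(-c2cccc(C)c2)nn1` departs from compound 1 in one place: 3-methylphenyl in place of 2-methoxyphenyl on an aromatic nitrogen is the difference, which is 3-methylphenyl in place of 2-methoxyphenyl on an aromatic nitrogen of a five-membered aromatic ring with 3 nitrogen.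

The nearest evidence comes from exchanges on an aromatic carbon, where trifluoromethyl or nitro replaces methoxy and nitro replaces trifluoromethyl. These are a step that the two limits leave unreadable from compound 1 to compound 2 and a step that the two limits leave unreadable from compound 1 to compound 3 and also a step that the two limits leave unreadable from compound 2 to compound 3 in the same series. None of them gives a size, and none makes the exchange found in compound 4. No step beyond the scatter is therefore expected in this assay and no direction can be set.

The expected step is a number no higher from compound 1 to compound 4 (the limit leaves the size open) as an estimate only. For compound 4 the estimated value is 150000 nM with an expected range from 60000 nM to 300000 nM and another report as a limit is the likeliest outcome.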

Compound 4, half-maximal inhibitory concentration: 137000 nM
Estimate against measurement, compound 4: 1.1-fold (0.04 log units) above; measured number inside the range.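

In this assay compound 4 gives 137000 nM, a number rather than a limit of the assay, so this place on the aromatic nitrogen can carry a group, 3-methylphenyl, that yields a readable value. The exchange gives an at least 1.0-fold lower number from compound 1 to compound 4 (0.03 log units; that floor lies within the scatter), an at least 1.0-fold lower number from compound 3 to compound 4 (0.03 log units; that floor lies within the scatter) and an at least 1.0-fold lower number from compound 2 to compound 4 (0.03 log units; that floor lies within the scatter), and since each of these floors lies within the scatter, the series shows that a value now exists, not that any real gain in strength has been made. Compound 4 therefore stands alone against the common mark of the set: the limit of > 150000 nM in this assay, at which 3 of the 4 values shown sit.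

On these data alone, whether the number comes from the methyl group, from where it sits on the phenyl group, or from the absence of methoxy, nitro or trifluoromethyl stays open, for each exchange replaces the whole substituted phenyl group at once. The compounds shown also do not tell how an amine or a carboxylic acid on the phenyl group, or a longer chain in place of the methyl, would read in this assay.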